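The source may report more compounds than this note shows. Statements on the series, on what has been measured and on what is new or still open speak of the compounds shown alone.

In an ADME assay for permeability, using PAMPA, with a stated time of 4 h, at pH 7.4, tested at 100 uM (a lower number here means that the compound crosses the layer more slowly, a higher number that the compound crosses the layer faster), compound 1 `Cc1nc2cc(-c3ccccc3)nn2c(N2CCC(C)(C)CC2)c1C(OC(C)(C)C)C(=O)O` gives 703 nm/s, compound 2 `Cc1nc2cc(-c3cccc(-c4ccccc4)c3)nn2c(-c2cc(F)c3c(c2C)CCCO3)c1C(OC(C)(C)C)C(=O)O` gives 652 nm/s and compound 3 `Cc1ccccc1-c1cccc(-c2cc3nc(C)c([C@H](OC(C)(C)C)C(=O)O)c(-c4cc(F)c5c(c4C)CCCO5)n3n2)c1` gives 471 nm/s. Compound 3 lies within the usual scatter of both compound 1 and compound 2, so the three numbers read as one group. Compound 4 `Cc1nc2cc(-c3cccc(-c4ccccc4F)c3)nn2c(-c2cc(F)c3c(c2C)CCCO3)c1[C@H](OC(C)(C)C)C(=O)O` carries one change from compound 3: fluoro in place of methyl on an aromatic carbon, ortho to a large group. Among the compounds with values here, no measured pair differs in one place, so this change has no direct precedent in this assay. No shift beyond the scatter is expected, in either direction. The expected step, a 1.1-fold higher number from compound 3 to compound 4 (0.03 log units; within the scatter), is small. For compound 4 the estimate is 500 nm/s, with an expected range of 300 nm/s to 800 nm/s.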

Compound 4, apparent permeability: 608 nm/s
Beside the measured number, compound 4's estimate is 1.2-fold (0.08 log units) below it; the range from low to high includes it.
By their numbers in this assay, from the lowest: compounds 3, 4, 2 and 1 (each within the scatter of the next).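

In this assay, within the data shown here, the change from 2-methylphenyl to 2-fluorophenyl provides the first pair that differs in one place, with a 1.3-fold higher number from compound 3 to compound 4 (0.11 log units; within the scatter) for fluoro in place of methyl on an aromatic carbon, ortho to a large group. At this position, in this one pair, the change leaves the read-out within the scatter. No measurement at hand explains the result. As far as these compounds go, whether an amine, a methoxy group or a nitrile at the same place would also stay within the scatter remains open. Also open, from the compounds shown here alone, is whether fluoro in place of methyl gives a similar step elsewhere.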